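This account rests on a few compounds, and the source may have more. Where it says the series, first, only, none or still open, it means among the compounds named here.

Measured compounds, all in a functional assay on MDA-MB-231 cells (Homo sapiens) for cytotoxicity, read by MTT assay, with a stated time of 72 h; a lower number here means a stronger inhibitor, a higher number a weaker inhibitor:

- compound 1 `CN(C)Cc1ccc2nc(NC(=O)N/N=C/c3cn(Cc4ccc(Cl)cc4Cl)c4ccccc34)sc2c1` — compound 1 gives 1410 nM
- compound 2 `CN(C)Cc1ccc2nc(NC(=O)N/N=C/c3cn(Cc4ccc(C(C)(C)C)cc4)c4ccccc34)sc2c1` — compound 2 gives 2230 nM
- compound 3 `CN(C)Cc1ccc2nc(NC(=O)N/N=C/c3cn(Cc4cccc(Cl)c4)c4ccccc34)sc2c1` — compound 3 gives 1140 nM

Compound 3 holds the lowest of the three numbers, but its neighbours sit close: a 1.2-fold lower number from compound 1 to compound 3 (0.09 log units; within the scatter), and a 2.0-fold lower number from compound 2 to compound 3 (0.29 log units; within the scatter). The third measured step, a 1.6-fold higher number from compound 1 to compound 2 (0.20 log units; within the scatter), is likewise within the scatter. Across the three benzyl variants the series has so far shown no movement beyond the scatter in this assay.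

Compound 4 `CN(C)Cc1ccc2nc(NC(=O)N/N=C/c3cn(Cc4ccc(Cl)c(Cl)c4)c4ccccc34)sc2c1` is not yet measured. It differs from compound 3 by chloro in place of hydrogen on an aromatic carbon, that is, 3-chlorobenzyl to 3,4-dichlorobenzyl. The step that bears most directly on it is a 1.2-fold lower number from compound 1 to compound 3 (0.09 log units; within the scatter), where the arrangement of two chlorines against one on the same ring gave a change within the scatter; the steps involving compound 2 add a second chloro-free variant with the same outcome. Going by the values given here, nothing among the measured steps suggests that adding a chloro group moves the number beyond the scatter in either direction.

The expected step is therefore a 1.1-fold higher number from compound 3 to compound 4 (0.02 log units; within the scatter), essentially no shift. The estimated value for compound 4 in this assay is 1200 nM, with a range from 600 nM to 2500 nM.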

Compound 4, half-maximal inhibitory concentration: 1000 nM
Compound 4: the middle estimate sits 1.2-fold (0.08 log units) above what was measured; measured number inside the range.
By their numbers in this assay, from the lowest: compounds 4, 3, 1 and 2 (each within the scatter of the next, the first and the last beyond it).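

Adding a chloro group ortho to a chloro group and para to a large group, 3-chlorobenzyl to 3,4-dichlorobenzyl, gives in this assay a single-change reading for this position: a 1.1-fold lower number from compound 3 to compound 4 (0.06 log units; within the scatter) and so no measurable effect of this change. Relocating one chlorine of the dichlorinated ring is also flat, with a 1.4-fold lower number from compound 1 to compound 4 (0.15 log units; within the scatter) as the step between the 2,4-dichlorophenyl and 3,4-dichlorophenyl variants. The series now has its first separation beyond the scatter, a 2.2-fold lower number from compound 2 to compound 4 (0.35 log units; beyond the scatter) and modest in size, yet this is no general advantage of chlorinated rings over 4-(tert-butyl)phenyl, as compound 1 and compound 3 both remain within the scatter of compound 2, and no evidence is available to explain this gap.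

The compounds shown carry only chloro and tert-butyl groups on the benzyl ring, leaving open whether a methoxy group, a nitrile, a carboxylic acid or an amine at the same carbon would shift the number beyond the scatter. The unsubstituted benzyl group is also absent as a reference, and every comparison here leaves the shared core unchanged.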